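Phenoxy in place of chloro at the assay limit

The source may hold more compounds than are shown below. What is called first, only, known or untested is meant among the compounds shown, and "the series" means these compounds.

Compound 1 `COc1ccc(/C=C/C(=O)/C=C/c2cc3ccccc3nc2Cl)c(OC)c1` gives > 10000 nM
Compound 2 `COc1cc(OC)c(/C=C/C(=O)/C=C/c2cc3ccccc3nc2Cl)c(OC)c1` gives > 10000 nM
Compound 3 `COc1ccc(/C=C/C(=O)/C=C/c2cc3ccccc3nc2Oc2ccccc2)cc1OC` gives > 10000 nM

In a functional assay on HGC-27 cells (Homo sapiens) for cytotoxicity, read by MTT assay, with a stated time of 48 h (a higher number here means a weaker inhibitor, a lower number a stronger inhibitor), compound 2 gives > 10000 nM as a limit and not a number. Compound 2 thus stands at the limit of > 10000 nM in this assay, at which 3 of the 3 values shown sit, without a rank. Compound 4 `COc1cc(OC)c(/C=C/C(=O)/C=C/c2cc3ccccc3nc2Oc2ccccc2)c(OC)c1` differs from it by phenoxy in place of chloro on an aromatic carbon in one place, phenoxy in place of chloro on an aromatic carbon next to the ring nitrogen. For the measured compounds named here, the only measured step that the two limits leave unreadable from compound 1 to compound 2 is another change and gives no size. Compound 3 also carries phenoxy and gives > 10000 nM as a limit too. With no readable step, no shift beyond the usual scatter is expected in this assay and no direction can be named. The expected result is a step that the limit leaves unreadable from compound 2 to compound 4 in this estimate. Compound 4 is estimated at 12000 nM with 4000 nM and 30000 nM as the expected ends of its range.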

Compound 4, half-maximal inhibitory concentration: > 10000 nM
Compound 4 was reported as a limit (the forecaster's own chance of this, stated with the estimate: 75%); the middle value lies beyond the limit too.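

For the compounds shown here, compound 2 and compound 4 each give a limit and not a number, so no step between them can be read: the limit of > 10000 nM in this assay, at which 4 of the 4 values shown sit. The compounds shown leave open how strongly each one acts and whether phenoxy in place of chloro changes anything.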